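Swapping a benzyl nitrile for a halogenated benzyl

A few compounds are considered here, and "the series" means these few. Any claim that something is new, unique, unknown or untested is made for them only; others in the source may bear on it.

Measured compounds:
- compound 1, `O=c1c2cnn(-c3ccc(F)cc3)c2ncn1CC1(O)CCN(Cc2ccncc2)CC1`: "not determined" (no result reported)
- compound 2, `O=c1c2cnn(-c3ccc(F)cc3)c2ncn1CC1(O)CCN(Cc2cccc(Cl)c2)CC1`: "not determined" (no result reported)
- compound 3, `N#Cc1ccccc1CN1CCC(O)(Cn2cnc3c(cnn3-c3ccc(F)cc3)c2=O)CC1`: 8100 nM

Three compounds share one core and differ only in the group carried on a saturated chain carbon bound to an amine nitrogen in a ring. Within the data shown here, compound 1 and compound 2 have no reported result, so compound 3 is the only one with a number: in an assay on Sf21 cells for inhibition of ubiquitin carboxyl-terminal hydrolase 7 (Homo sapiens), read by spectrophotometry, with stated times of 30 min and 2 h (on this read-out lower numbers stand for stronger inhibition and higher numbers for weaker inhibition), compound 3 gives 8100 nM, a weak level of inhibition. Among the measured compounds shown here, no pair of measured compounds can be compared, so nothing is known about how changes at this position move the read-out.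

Compound 4, `O=c1c2cnn(-c3ccc(F)cc3)c2ncn1CC1(O)CCN(Cc2ccc(F)cc2Cl)CC1`, is the next compound to be tested. It differs from compound 3 in one place: 2-chloro-4-fluorophenyl in place of 2-cyanophenyl on a saturated chain carbon bound to an amine nitrogen in a ring. For the measured compounds named here, with no measured step to lean on, the expectation is a change of no more than the usual scatter, in no particular direction, giving a 1.2-fold lower number from compound 3 to compound 4 (0.06 log units; within the scatter) as the estimated step. For compound 4 in this assay the estimate is 7000 nM, expected to lie between 1800 nM and 28000 nM.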

Compound 4, half-maximal inhibitory concentration: 1600 nM
Beside the measured number, compound 4's estimate is 4.4-fold (0.64 log units) above it; measured number below the stated range.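

In this assay, among these compounds, putting 2-chloro-4-fluorophenyl in place of 2-cyanophenyl gives a 5.1-fold lower number from compound 3 to compound 4 (0.70 log units; beyond the scatter), the first sign that the group at this position can move the read-out by more than the scatter. The change removes the nitrile and adds both chlorine and fluorine in one move, so this single step cannot show which of these differences matters. Nothing measured here explains the gain in inhibition.

Going by these compounds, it remains open whether a phenyl carrying only the chlorine or only the fluorine would match the number for compound 4. On these data alone, it is also open how other groups at this position, such as a methoxy-substituted phenyl, a cyclohexyl ring or a simple longer alkyl chain, would compare.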